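The compounds below may be only part of what the source reports. "The series", "measured", "known", "first", "only" and "open" are said of these compounds alone.

Working notes on the series. Compound 1 `CCc1nnc(SCC(=O)c2ccc(C)cc2)n1N1C(=O)c2ccccc2C1=O`, compound 2 `CCCc1nnc(SCC(=O)c2ccc(C)cc2)n1N1C(=O)c2ccccc2C1=O` and compound 3 `COc1cc(-c2nnc(SCC(=O)c3ccc(C)cc3)n2N2C(=O)c3ccccc3C2=O)cc(OC)c1OC` share one core. In a functional assay on HepG2 cells (Homo sapiens) for cytotoxicity, read by MTT assay, with a stated time of 48 h (on this read-out lower numbers stand for stronger inhibition and higher numbers for weaker inhibition), compound 1 gives only a limit, > 200000 nM. Compound 2 likewise gives a limit, > 200000 nM. Going by the values given here, compound 3 gives 9440 nM, the only number in the set, the two others sitting at the limit of > 200000 nM in this assay, at which 2 of the 3 values shown sit. Compound 3 shows an at least 21-fold lower number from compound 1 to compound 3 (1.32 log units; beyond the scatter) and an at least 21-fold lower number from compound 2 to compound 3 (1.32 log units; beyond the scatter), both on the core position that carries the 3,4,5-trimethoxyphenyl. Among the compounds with values here, compound 4 `COc1cc(-c2nnc(SCC(=O)c3ccc(F)cc3)n2N2C(=O)c3ccccc3C2=O)cc(OC)c1OC` differs from compound 3 by fluoro in place of methyl on an aromatic carbon, on the (4-methylphenyl)carbonyl side; no measured step touches that position, so the steps seen give no guide to its size. No step beyond the scatter is therefore expected in this assay, a 1.1-fold higher number from compound 3 to compound 4 (0.03 log units; within the scatter). Compound 4 is estimated at 10000 nM, between 3000 nM and 35000 nM.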

Compound 4, half-maximal inhibitory concentration: > 200000 nM
Compound 4: only a limit was reported; the forecaster's own chance of this, stated with the estimate: 10%; at least 20-fold (1.30 log units) between middle value and limit.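

In this assay, the position on the (4-methylphenyl)carbonyl side, untouched by earlier steps, turns out to matter: fluoro in place of methyl on this aromatic carbon gives an at least 21-fold higher number from compound 3 to compound 4 (1.32 log units; beyond the scatter). The 3,4,5-trimethoxyphenyl alone therefore does not secure a measurable number, since compound 4 carries it and still gives only a limit. Compound 3 now stands alone with a number: the limit of > 200000 nM in this assay, at which 3 of the 4 values shown sit.

Going by these compounds, the true size of the step stays unknown, as compound 4 is a limit. On these data alone, whether chloro, methoxy or an amine on this aromatic carbon keeps a measurable number remains open.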